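Swapping bromo for fluoro in compound 3

The source may report more compounds than this note shows. Statements on the series, on what has been measured and on what is new or still open speak of the compounds shown alone.

Compound 3 `O=S(=O)(c1ccc(Br)cc1)c1nc2ccccc2nc1N1CCc2ccccc2C1` has no exact number in a functional assay on KB cells (Homo sapiens) for cytotoxicity, read by MTT assay, with a stated time of 72 h; on this read-out lower numbers stand for stronger inhibition and higher numbers for weaker inhibition: its result is only a limit, > 50000 nM. Its closest relative with a real number is compound 2 `O=S(=O)(c1ccccc1)c1nc2ccccc2nc1N1CCc2ccccc2C1`, which gives 26300 nM in this assay.

Compound 4 `O=S(=O)(c1ccc(F)cc1)c1nc2ccccc2nc1N1CCc2ccccc2C1` differs from compound 3 by a single swap, (fluoro in place of bromo on an aromatic carbon). This puts fluoro in place of bromo on an aromatic carbon, so 4-bromophenyl becomes 4-fluorophenyl.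

Going by the values given here, one measured step bears on this swap: an at least 1.9-fold higher number from compound 2 to compound 3 (0.27 log units; that floor lies within the scatter). It comes from bromo in place of hydrogen on the same kind of carbon, and it gives only a floor, not a true size. It therefore cannot show how much bromo matters. A second clue is compound 1 `O=S(=O)(c1ccc(F)cc1)c1nc2ccccc2nc1N1CCCC1`, which carries the same 4-fluorophenyl group on a different remainder and gives 30100 nM in this assay.

With compound 2 at 26300 nM and compound 1 at 30100 nM as guides, a modest move toward a lower number is expected, though it may not clear the scatter. The expected size is an at least 1.5-fold lower number from compound 3 to compound 4 (0.19 log units; that floor lies within the scatter). For compound 4 the estimate is 32000 nM, with an expected range from 14000 nM to 60000 nM.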

Compound 4, half-maximal inhibitory concentration: 35400 nM
Estimate against measurement, compound 4: 1.1-fold (0.04 log units) below; the range from low to high includes it.
By their numbers in this assay, from the lowest: compounds 2, 1 and 4 (each within the scatter of the next). At a limit, above all of these: compound 3.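

In this assay, fluoro in place of bromo gives an at least 1.4-fold lower number from compound 3 to compound 4 (0.14 log units; that floor lies within the scatter), so the 4-fluorophenyl compound has an exact number, but the true size of this swap still cannot be read. Fluoro in place of hydrogen on this aromatic carbon gives a 1.3-fold higher number from compound 2 to compound 4 (0.13 log units; within the scatter), so fluoro and hydrogen cannot be told apart here in this assay. With the 4-fluorophenyl group held constant, 1,2,3,4-tetrahydroisoquinolin-2-yl in place of pyrrolidin-1-yl gives a 1.2-fold higher number from compound 1 to compound 4 (0.07 log units; within the scatter), so this second change also cannot be told apart from repeat-measurement scatter.

On these data alone, how far compound 3 truly lies from the other compounds stays open because its result is a limit and not a number: the limit of > 50000 nM in this assay, at which 1 of the 4 values shown sits. It also stays open whether a different group on this aromatic carbon, such as an amine, a carboxylic acid or a methoxy group, would give a number clearly apart from these.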